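Shifting the anilino substituent in a bromopyrimidine series

The source may hold more compounds than are shown below. What is called first, only, known or untested is meant among the compounds shown, and "the series" means these compounds.

Measured so far:
Compound 1 `CNC(=O)c1ccccc1Oc1nc(Nc2ccccc2OC)ncc1Br`: 52100 nM
Compound 2 `CNC(=O)c1ccccc1Oc1nc(Nc2cccc(C)c2)ncc1Br`: 15900 nM
Compound 3 `CNC(=O)c1ccccc1Oc1nc(Nc2ccc(C)cc2C)ncc1Br`: 49600 nM

The three compounds share one core and differ only in the aryl group on the nitrogen on an aromatic ring. In a functional assay on U-937 cells (Homo sapiens) for antiproliferative activity, read by MTT assay, with a stated time of 24 h (on this read-out lower numbers stand for stronger inhibition and higher numbers for weaker inhibition), compound 3 is the second highest of the three numbers; its nearest neighbour is compound 1, separated by a gap within the scatter (a 1.1-fold lower number from compound 1 to compound 3 (0.02 log units; within the scatter)), while compound 2 is furthest, since a 3.1-fold higher number from compound 2 to compound 3 (0.49 log units; beyond the scatter).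

Compound 4 `CNC(=O)c1ccccc1Oc1nc(Nc2cccc(OC)c2)ncc1Br` has not yet been tested. The change from compound 3 is 3-methoxyphenyl in place of 2,4-dimethylphenyl on a nitrogen on an aromatic ring. Going by the values given here, two measured steps bear on it. The step of a 3.1-fold higher number from compound 2 to compound 3 (0.49 log units; beyond the scatter) shows that going from a 3-substituted phenyl to 2,4-dimethylphenyl raised the number modestly; the step of a 3.3-fold lower number from compound 1 to compound 2 (0.52 log units; beyond the scatter) shows the 3-methyl pattern giving a lower number than a 2-substituted pattern. Compound 4 carries its single substituent in the same 3-position pattern as compound 2, so a modest step downward, a 2.5-fold lower number from compound 3 to compound 4 (0.39 log units; beyond the scatter), is expected.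

Compound 4 is estimated at 20000 nM, with a range of 8000 nM to 55000 nM.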

Compound 4, half-maximal inhibitory concentration: 24300 nM
The estimate for compound 4 lay 1.2-fold (0.08 log units) below the measured number, and the stated range covers the measured number.
By their numbers in this assay, from the lowest: compounds 2 and 4 (each within the scatter of the next); then compounds 3 and 1 (each within the scatter of the next).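

In this assay, 3-methoxyphenyl in place of 2-methoxyphenyl gives a 2.1-fold lower number from compound 1 to compound 4 (0.33 log units; beyond the scatter) and so shows that the same methoxy group gives different numbers at two places on this aryl ring. Methoxy in place of methyl gives a 1.5-fold higher number from compound 2 to compound 4 (0.18 log units; within the scatter) and leaves compound 2 and compound 4 indistinguishable, so at this one place the two groups cannot be told apart in this assay. The step of a 2.0-fold lower number from compound 3 to compound 4 (0.31 log units; beyond the scatter) is also modest, but it changes both the groups and their places, so it cannot be assigned to either alone.

Nothing measured here gives a reason for these steps. Still open, going by these compounds, is whether an amine, a carboxylic acid or a longer chain such as ethoxy at the place named in 3-methoxyphenyl would match compound 2 and compound 4 or differ from them.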